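The source may report more compounds than this note shows. Statements on the series, on what has been measured and on what is new or still open speak of the compounds shown alone.

Of the compounds shown here, three have been measured in an ADME assay on HCT-116 cells (Homo sapiens) for antiproliferative activity; on this read-out higher numbers stand for weaker inhibition and lower numbers for stronger inhibition. Compound 1 `COc1ccc(C(N)=O)cc1COc1ccc(Cl)c(C)c1` gives > 50000 nM, which is a limit of the assay and not a number. Compound 2 `COc1ccc(C(N)=O)cc1COc1ccc(Cl)cc1` gives > 50000 nM, again a limit. The picture so far is therefore framed by the limit of > 50000 nM in this assay, at which 2 of the 3 values shown sit. Within the data shown here, compound 3 `COc1ccc(C(N)=O)cc1/C=C/c1ccc(C(F)(F)F)cc1` gives 35000 nM, the only true number in the set, so it stands alone, with no other measured number to set it against.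

The next compound, compound 4 `COc1ccc(/C=C/c2cc(C(N)=O)ccc2OC)cc1`, differs from compound 3 in one place: methoxy in place of trifluoromethyl on an aromatic carbon. In words, this is methoxy in place of trifluoromethyl on an aromatic carbon, para to a large group.

Among the measured compounds shown here, only one measured step exists to draw on, a step that the two limits leave unreadable from compound 1 to compound 2. It has no readable size, and it concerns hydrogen in place of methyl rather than this exchange, so it offers no guide to size or direction. With nothing measured that speaks to the change, no shift beyond the usual scatter in this assay is expected, and compound 3 at 35000 nM remains the anchor. The expected move is a 1.2-fold lower number from compound 3 to compound 4 (0.07 log units; within the scatter). Compound 4 is estimated at 30000 nM, with an expected range from 12000 nM to 60000 nM.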

Compound 4, half-maximal inhibitory concentration: 19000 nM
Compound 4: the middle estimate sits 1.6-fold (0.20 log units) above what was measured; the range from low to high includes it.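

Among these compounds, the exchange of trifluoromethyl for methoxy, on an aromatic carbon para to a large group, gives the first step of readable size in this assay: it is a 1.8-fold lower number from compound 3 to compound 4 (0.27 log units; within the scatter). Compound 3 and compound 4 therefore cannot be told apart on this read-out, even though the two groups differ in their heavy atoms and in their hydrogen-bond acceptors, so at this position the exchange shows no effect that stands clear of the usual scatter. Compound 1 and compound 2 each remain at a limit of the assay and not a number, and the step between them cannot be read, so this exchange is the only one with a size so far: the limit of > 50000 nM in this assay, at which 2 of the 4 values shown sit.

Among the compounds shown here, whether an amine or a carboxylic acid at this position would move the number beyond the scatter stays open, since trifluoromethyl and methoxy are the only two groups compared here. Also open is whether the same exchange would read the same way on the core of compound 1, where no pair with this change is shown.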